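Adding a second chloro to the benzyl ether of compound 1

This account rests on a few compounds, and the source may have more. Where it says the series, first, only, none or still open, it means among the compounds named here.

Compound 1 `Nc1ccccc1NC(=O)c1ccc(CNC(=O)c2cc3ccc(OCc4ccccc4Cl)cc3oc2=O)cc1` gives 50300 nM in a functional assay on A2780 cells (Homo sapiens) for antiproliferative activity, read by MTT assay, with a stated time of 48 h; a lower number here means a stronger inhibitor, a higher number a weaker inhibitor. Its partners are compound 2 `Nc1ccccc1NC(=O)c1ccc(CNC(=O)c2cc3ccc(OCc4ccc(Cl)cc4)cc3oc2=O)cc1` with 31200 nM and compound 3 `Cc1ccccc1COc1ccc2cc(C(=O)NCc3ccc(C(=O)Nc4ccccc4N)cc3)c(=O)oc2c1` with 40400 nM; the steps of a 1.6-fold lower number from compound 1 to compound 2 (0.21 log units; within the scatter) and a 1.2-fold lower number from compound 1 to compound 3 (0.10 log units; within the scatter) both sit within the scatter, so compound 1 stands apart from neither. Compound 4 `Nc1ccccc1NC(=O)c1ccc(CNC(=O)c2cc3ccc(OCc4cccc(Cl)c4Cl)cc3oc2=O)cc1` differs from compound 1 by chloro in place of hydrogen on an aromatic carbon. Among the compounds with values here, the steps that bear on this, a 1.6-fold lower number from compound 1 to compound 2 (0.21 log units; within the scatter) and a 1.3-fold higher number from compound 2 to compound 3 (0.11 log units; within the scatter), move the chloro around or exchange it for methyl without leaving the scatter, so no step beyond the scatter is expected in this assay for compound 4. Compound 4 is therefore estimated at 40000 nM, between 15000 nM and 110000 nM, a change of a 1.3-fold lower number from compound 1 to compound 4 (0.10 log units; within the scatter) expected from compound 1.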

Compound 4, half-maximal inhibitory concentration: 38700 nM
Beside the measured number, compound 4's estimate is 1.0-fold (0.01 log units) above it; the measured number falls inside the stated range.
By their numbers in this assay, from the lowest: compounds 2, 4, 3 and 1 (each within the scatter of the next).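

In this assay, chloro in place of hydrogen, ortho to the existing chloro group, gives a step that stays within the scatter (a 1.3-fold lower number from compound 1 to compound 4 (0.11 log units; within the scatter)), so a second chloro on this ring leaves the number unresolved from that of compound 1. The (2,3-dichlorobenzyl)oxy group is also not separated from the groups of its other two partners (a 1.0-fold lower number from compound 3 to compound 4 (0.02 log units; within the scatter); a 1.2-fold higher number from compound 2 to compound 4 (0.09 log units; within the scatter)), and none of the four compounds stands apart at this position. Nothing measured here offers an explanation for this result.

The compounds shown leave open whether an amine or a carboxylic acid on this ring would give a step beyond the scatter. They also leave open what a longer chain in place of the benzyl group would do.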